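Swapping the Terminal Amide Ring in an Oxytocin Receptor Series

This account rests on a few compounds, and the source may have more. Where it says the series, first, only, none or still open, it means among the compounds named here.

Within the data shown here, compound 2 `Cc1nc([C@H](C(=O)N2CCC2)N2C(=O)[C@@H](C3Cc4ccccc4C3)NC(=O)[C@H]2CC(C)C)co1` has the higher of the two numbers measured so far in an assay on isolated protein for binding affinity to Oxytocin receptor (Homo sapiens) (on this read-out higher numbers stand for weaker inhibition and lower numbers for stronger inhibition), where compound 2 gives 1.59 nM; compound 1 `Cc1nc([C@H](C(=O)NC(C)C)N2C(=O)[C@@H](C3Cc4ccccc4C3)NC(=O)[C@H]2CC(C)C)co1` gives 1.26 nM, and the step of a 1.3-fold higher number from compound 1 to compound 2 (0.10 log units; within the scatter) lies within the scatter. Compound 3 `Cc1nc([C@H](C(=O)N2CCOCC2)N2C(=O)[C@@H](C3Cc4ccccc4C3)NC(=O)[C@H]2CC(C)C)co1` differs from compound 2 by morpholin-4-yl in place of azetidin-1-yl on a carbonyl carbon. Among the measured compounds shown here, the only step that bears on this change, the earlier swap of the amide substituent, was small, so no shift beyond the scatter is expected in this assay. Compound 3 is therefore estimated at 2 nM, between 0.8 nM and 5 nM. This expectation corresponds to a step of a 1.3-fold higher number from compound 2 to compound 3 (0.10 log units; within the scatter).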

Compound 3, inhibition constant in the Oxytocin receptor assay: 2 nM
Compound 3: the middle estimate sits on the measured number at the digits printed; the range from low to high includes it.
By their numbers in the Oxytocin receptor assay, from the lowest: compounds 1, 2 and 3 (each within the scatter of the next).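

In the Oxytocin receptor assay, morpholin-4-yl on a carbonyl carbon brings a six-membered ring and a hydrogen-bond acceptor that azetidin-1-yl lacks, yet the change gives a 1.3-fold higher number from compound 2 to compound 3 (0.10 log units; within the scatter) and, set against isopropylamino, a 1.6-fold higher number from compound 1 to compound 3 (0.20 log units; within the scatter), so this position takes all three groups within the scatter. In a physicochemical assay for solubility (a lower number here means a less soluble compound, a higher number a more soluble compound), compound 2 gives > 220 ug/mL, which is a limit of the assay. In the physicochemical assay compound 3 gives > 220 ug/mL, which is also a limit of the assay. In the physicochemical assay the step from compound 2 to compound 3 cannot be read, since both values are limits of the assay: the limit of > 220 ug/mL in the physicochemical assay, at which 2 of the 2 values shown sit.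

Going by these compounds, whether piperazin-1-yl or a carboxylic acid on the same carbonyl carbon would also stay within the scatter in the Oxytocin receptor assay remains open. On these data alone, the actual solubility of compound 2 and compound 3 also remains open.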